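Acetylated nucleoside series: aryl substituent changes at the ring

The source may hold more compounds than are shown below. What is called first, only, known or untested is meant among the compounds shown, and "the series" means these compounds.

Measured so far:
compound 1, `CCCc1cc(-c2cn([C@H]3C[C@H](OC(C)=O)[C@@H](COC(C)=O)O3)c(=O)[nH]c2=O)on1`, 88.1%
compound 2, `CC(=O)OC[C@H]1O[C@@H](n2cc(-c3cc(-c4ccccc4)no3)c(=O)[nH]c2=O)C[C@@H]1OC(C)=O`, 85.5%
compound 3, `CC(C)(C)c1ccc(-c2cc(-c3cn([C@H]4C[C@H](O)[C@@H](CO)O4)c(=O)[nH]c3=O)on2)cc1`, 87.9%

In a functional assay on PC-3 cells (Homo sapiens) for cytotoxicity, read by sulforhodamine B assay, tested at 10 uM (a higher number here means more inhibition at the concentration tested (going by the name of the read-out), a lower number less inhibition), compound 2 gives 85.5%. Its value sits within the usual scatter of both compound 1 and compound 3; no ordering among the three can be read from these numbers. Among the compounds with values here, the one measured step that changes a single place, phenyl in place of propyl on an aromatic carbon, is a number 2.6 percentage points lower from compound 1 to compound 2 (within the scatter). Compound 3 differs from compound 2 in more than one place, so only its value can be set beside that of compound 2, and the two lie within the scatter.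

Compound 4, `CCCCc1ccc(-c2cc(-c3cn([C@H]4C[C@H](OC(C)=O)[C@@H](COC(C)=O)O4)c(=O)[nH]c3=O)on2)cc1`, awaits measurement in this assay. It differs from compound 2 as follows: butyl in place of hydrogen on an aromatic carbon.

The step from compound 1 to compound 2 exchanges one carbon chain for an aromatic ring at this part of the molecule without a change beyond the scatter, and compound 3, which carries a different alkyl-substituted aryl group at the same place, also falls within the scatter of compound 2. On that basis a change at this position is expected to leave the read-out within the scatter, so the step from compound 2 to compound 4 is estimated as a number 1.5 percentage points higher from compound 2 to compound 4 (within the scatter). For compound 4 the expected value is 87%, with a likely range from 78% to 94%.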

Compound 4, a percentage reported as inhibition, at one concentration (the size of the read-out at that concentration, not a potency): 30.4%
Compound 4: middle estimate off by 56.6 percentage points, on the high side; measured number below the stated range.
By their numbers in this assay, from the lowest: compound 4; then compounds 2, 3 and 1 (each within the scatter of the next).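

In this assay, within the data shown here, the place on the phenyl ring para to a large group proves sensitive: butyl in place of hydrogen gives a number 55.1 percentage points lower from compound 2 to compound 4 (beyond the scatter) and so separates compound 4 from the earlier compounds. The exchange of propyl for 4-butylphenyl gives a number 57.7 percentage points lower from compound 1 to compound 4 (beyond the scatter), whereas phenyl in place of propyl gives only a number 2.6 percentage points lower from compound 1 to compound 2 (within the scatter), so within these three compounds the large drop appears only once the butyl is present on the phenyl ring, and the phenyl alone does not produce it. No data at hand give a reason for this drop.

The compounds shown leave open whether a methyl, an ethyl or a longer chain such as hexyl at this carbon would give a similar read-out, and whether an amine or a carboxylic acid there would behave differently from butyl. Compound 3 differs from compound 4 in more than one place, so it leaves open whether the drop depends on the form of the alkyl group or on the acetyl groups of the sugar.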